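A few compounds are considered here, and "the series" means these few. Any claim that something is new, unique, unknown or untested is made for them only; others in the source may bear on it.

Measured so far:
compound 1, `C=CCOc1ccc(Br)cc1C(=O)c1cccnc1`, with 88000 nM;
compound 2, `C=CCOc1ccc(C)cc1C(=O)c1cccnc1`, with 87000 nM;
compound 3, `Cc1ccc(O)c(C(=O)c2cccnc2)c1`, with 5540 nM.

All three were tested in a functional assay on IMR-32 cells (Homo sapiens) for cytotoxicity, read by sulforhodamine B assay, with a stated time of 48 h; a higher number here means a weaker inhibitor, a lower number a stronger inhibitor. Compound 1 and compound 2 share a core and differ in one place: bromo in place of methyl on an aromatic carbon. The step of a 1.0-fold higher number from compound 2 to compound 1 (0.00 log units; within the scatter) shows that this exchange left the number essentially unchanged. Compound 2 and compound 3 differ elsewhere: hydrogen in place of allyl on an oxygen on an aromatic ring. Here the step of a 16-fold lower number from compound 2 to compound 3 (1.20 log units; beyond the scatter) is large and carries the number well beyond the scatter, and compound 3 stands with the lowest number of the three.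

Compound 4, `O=C(c1cccnc1)c1cc(Br)ccc1O`, has not yet been measured. It differs from compound 3 by bromo in place of methyl on an aromatic carbon. Among the compounds with values here, this is the same kind of change as the one from compound 2 to compound 1, but not the same: in compound 2 the exchanged carbon sits para to an allyloxy group (4 heavy atoms), whereas in compound 3 it sits para to a hydroxy group (1 heavy atom), and the two cores differ by hydrogen in place of allyl on an oxygen on an aromatic ring. Resting on a 1.0-fold higher number from compound 2 to compound 1 (0.00 log units; within the scatter), which stayed within the scatter, the step from compound 3 to compound 4 is expected to be small as well, estimated at a 1.0-fold lower number from compound 3 to compound 4 (0.00 log units; within the scatter). Compound 4 is therefore estimated to give 5500 nM in this assay, most likely between 2500 nM and 12000 nM.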

Compound 4, half-maximal inhibitory concentration: 23400 nM
Compound 4: middle estimate off by 4.3-fold (0.63 log units), on the low side; measured number outside the range, above it.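

In this assay, the exchange of methyl for bromo did not carry over from one core to the other. Where the oxygen bears a hydrogen it gives a 4.2-fold higher number from compound 3 to compound 4 (0.63 log units; beyond the scatter), while the two steps on the two cores compare as follows: the same change on two cores in this assay, a 1.0-fold higher number (0.00 log units; within the scatter) from compound 2 to compound 1 and a 4.2-fold higher number (0.63 log units; beyond the scatter) from compound 3 to compound 4, 4.2-fold (0.62 log units) apart, beyond the scatter of two such steps Removing the allyl group from the oxygen also depends on the core, giving a 3.8-fold lower number from compound 1 to compound 4 (0.58 log units; beyond the scatter) with bromo on the ring, and the comparison with the methyl core reads: the same change on two cores in this assay, a 16-fold lower number (1.20 log units; beyond the scatter) from compound 2 to compound 3 and a 3.8-fold lower number (0.58 log units; beyond the scatter) from compound 1 to compound 4, 4.2-fold (0.62 log units) apart, beyond the scatter of two such steps These two comparisons are the same four compounds seen from two sides, so they show that the two changes do not simply add up in this small set, but they do not show why, and one such square gives no rule for how either change would behave on any other core.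

The compounds shown leave open whether chloro or fluoro on the same aromatic carbon would follow bromo or methyl, and whether the dependence on the core would persist. They also leave open where a methyl or a longer chain such as propyl on the oxygen would fall relative to the hydrogen and the allyl group.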